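A few compounds are considered here, and "the series" means these few. Any claim that something is new, unique, unknown or untested is made for them only; others in the source may bear on it.

Of the compounds shown here, two of a shared core have been measured in an assay on isolated protein for inhibition of Amine oxidase [flavin-containing] B (Homo sapiens), read by fluorescence, with a stated time of 20 min; on this read-out higher numbers stand for weaker inhibition and lower numbers for stronger inhibition. Compound 1 `CC/C(C)=N\Nc1nc(-c2cccc([N+](=O)[O-])c2)cs1` gives 351 nM. Compound 2 `CCCCCC/C(C)=N\Nc1nc(-c2cccc([N+](=O)[O-])c2)cs1` gives 626 nM, which is the higher of the two numbers, though the step of a 1.8-fold higher number from compound 1 to compound 2 (0.25 log units; within the scatter) stays within the scatter, so the two compounds cannot be told apart on potency.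

Compound 3 `C/C(=N/Nc1nc(-c2cccc([N+](=O)[O-])c2)cs1)C1CCCCC1` has not yet been measured. It differs from compound 2 in one place: cyclohexyl in place of hexyl on a carbon with a double bond to nitrogen. Among the measured compounds shown here, the only measured step that touches this part of the molecule is the one from compound 1 to compound 2, where a butyl replaced a hydrogen on the saturated chain carbon two bonds along from the carbon with the double bond to nitrogen, and that step stayed within the scatter. Folding the hexyl into a cyclohexyl on the carbon with the double bond to nitrogen is a different kind of change, and nothing measured here speaks directly to it. The expectation is therefore a step of a 1.3-fold lower number from compound 2 to compound 3 (0.10 log units; within the scatter), with compound 3 expected to give 500 nM, within a range from 200 nM to 1500 nM.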

Compound 3, half-maximal inhibitory concentration: 7.2 nM
For compound 3 the middle estimate is 69-fold (1.84 log units) above the measured one; the measured number lies below the stated range.
By their numbers in this assay, from the lowest: compound 3; then compounds 1 and 2 (each within the scatter of the next).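

In this assay the group on the carbon with a double bond to nitrogen turns out to matter far more than compounds 1 and 2 could show, since those two, with ethyl and hexyl at this place, cannot be told apart on potency. Putting cyclohexyl in place of hexyl gives an 87-fold lower number from compound 2 to compound 3 (1.94 log units; beyond the scatter) and so a clear gain in inhibition, and putting cyclohexyl in place of ethyl gives a 49-fold lower number from compound 1 to compound 3 (1.69 log units; beyond the scatter) in the same direction. Hexyl and cyclohexyl have the same count of heavy atoms, all carbon, so among these three compounds the stronger inhibition goes with the ring and not with the number of carbons in the group.

Nothing available here accounts for this gain in potency. From the compounds shown here alone, it also remains open whether a cyclopentyl ring, a phenyl ring, a branched chain such as isopropyl, or a ring holding an amine, such as piperidinyl, would give a similarly low number at this place.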